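Swapping 3-Methoxyphenyl for Pyridin-2-yl in Compound 3

The source may hold more compounds than are shown below. What is called first, only, known or untested is meant among the compounds shown, and "the series" means these compounds.

Among the compounds with values here, compound 2 `COc1cccc(C(C)NC(=O)COc2cc(C(F)(F)F)c3c(-c4ccccc4)nn(C)c3n2)c1` holds the lowest of the two numbers so far in a functional assay on isolated protein for antagonist activity at Orexin/Hypocretin receptor type 1 (Homo sapiens), read by fluorescence, FLIPR and calcium flux, with a stated time of 1 h (on this read-out higher numbers stand for weaker inhibition and lower numbers for stronger inhibition), at 20 nM. Within the data shown here, its only neighbour, compound 1 `COc1ccccc1C(C)NC(=O)COc1cc(C(F)(F)F)c2c(-c3ccccc3)nn(C)c2n1`, gives 274 nM. That step, a 14-fold lower number from compound 1 to compound 2 (1.14 log units; beyond the scatter), arose from 3-methoxyphenyl in place of 2-methoxyphenyl on a saturated chain carbon bound to an amide-type nitrogen and a saturated chain carbon. Compound 3 `CC(NC(=O)COc1cc(C(F)(F)F)c2c(-c3ccccc3)nn(C)c2n1)c1ccccn1` carries the change (pyridin-2-yl in place of 3-methoxyphenyl on a saturated chain carbon bound to an amide-type nitrogen and a saturated chain carbon). Among the measured compounds shown here, the single measured step concerns the methoxy position, not removal of the ring, so it offers only a loose guide. Compound 3 is therefore expected to land somewhat weaker, a 6.0-fold higher number from compound 2 to compound 3 (0.78 log units; beyond the scatter). The estimated value of compound 3 in this assay is 120 nM, within a range from 25 nM to 600 nM.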

Compound 3, inhibition constant: 2670 nM
Compound 3: the middle estimate sits 22-fold (1.35 log units) below what was measured; measured number above the stated range.
By their numbers in this assay, from the lowest: compound 2; then compound 1; then compound 3.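

In this assay, replacing the whole methoxyphenyl ring at this position with pyridin-2-yl moves the number much further than shifting the methoxy did, giving a 130-fold higher number from compound 2 to compound 3 (2.13 log units; beyond the scatter). The change also loses ground against the weaker methoxy isomer, with a 9.7-fold higher number from compound 1 to compound 3 (0.99 log units; beyond the scatter), so both methoxyphenyl groups give lower numbers here than pyridin-2-yl. No measurement at hand accounts for this loss.

The change swaps the ring carbon for nitrogen and removes the methoxy at once, and the compounds shown leave open which one carries the rise. Going by these compounds, how a plain phenyl or a pyridin-3-yl would read at this place also stays open.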